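A few compounds are considered here, and "the series" means these few. Any claim that something is new, unique, unknown or untested is made for them only; others in the source may bear on it.

Of the compounds shown here, two have numbers so far in an ADME assay on the whole organism (Mus musculus, strain BALB/c) for pharmacokinetics, read by LC-MS, with a stated time of 600 min, at a dose of 20 mg/kg by the oral route; a higher number here means more compound in the circulation at the dose given, a lower number less compound in the circulation. Compound 1 `CN(CCCNC(=O)Nc1ccc(C(C)(C)C)cc1)C[C@H]1C[C@@H](c2ccc3c(N)ncnn23)[C@H](O)[C@@H]1O` reaches 71.4 nM. Compound 2 `CC(C)NC[C@@H]1C[C@H](c2ccc3c(N)ncnn23)[C@@H](O)[C@H]1O` reaches 2110 nM, the higher of the two numbers, and its gap to compound 1 lies beyond the usual scatter. These two compounds differ in more than one place, so the gap cannot be assigned to any single change.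

The next compound to be read is compound 3 `CC(C)NC[C@H]1C[C@@H](c2ccc3c(N)ncnn23)[C@H](O)[C@@H]1O`, the mirror image of compound 2: the two compounds have the same atoms and bonds and differ only in configuration as drawn: 4 of 4 stereo elements differ (all stereocentres are inverted: mirror images); a stereocentre at a saturated ring carbon is drawn S in compound 2 and R in compound 3; a stereocentre at a saturated ring carbon is drawn R in compound 2 and S in compound 3; a stereocentre at a saturated ring carbon is drawn R in compound 2 and S in compound 3; a stereocentre at a saturated ring carbon is drawn S in compound 2 and R in compound 3. Within the data shown here, no measured pair isolates a change of configuration, so the data offer no direct precedent for the size of this step. Atoms and bonds stay the same, so the natural anchor is compound 2 at 2110 nM. No direction can be argued from the data, and no shift beyond the scatter is expected in this assay. The expected step of a 1.2-fold lower number from compound 2 to compound 3 (0.07 log units; within the scatter) is therefore small. Among the measured compounds shown here, with only two measured compounds, the range is kept wide. For compound 3 the estimated value is 1800 nM, with an expected range of 500 nM to 5000 nM.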

Compound 3, maximal plasma concentration: 1840 nM
Compound 3: the middle estimate sits 1.0-fold (0.01 log units) below what was measured; the range from low to high includes it.
By their numbers in this assay, from the lowest: compound 1; then compounds 3 and 2 (each within the scatter of the next).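

In this assay the two mirror images cannot be told apart: a 1.1-fold lower number from compound 2 to compound 3 (0.06 log units; within the scatter). Among these compounds, this is the first step that can be read as one kind of change, with the result attributable to configuration alone because nothing else varies: the fact that compounds 2 and 3 differ only in the configuration as drawn For this amine series, then, the full set of four stereocentres, taken together, does not separate the two compounds in this assay, so this read-out alone gives no ground for preferring either mirror image.

The pair covers only complete inversion, and it leaves open whether changing one stereocentre at a time, giving a diastereomer rather than a mirror image, would also leave the number within the scatter. It also leaves open how the number responds when the isopropyl group is replaced by a single change such as a longer chain or a carboxylic acid, which would begin to resolve the still unassigned gap to compound 1.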